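The source may report more compounds than this note shows. Statements on the series, on what has been measured and on what is new or still open speak of the compounds shown alone.

Within the data shown here, in a functional assay on A549 cells (Homo sapiens) for antiproliferative activity, read by MTT assay, with a stated time of 48 h (on this read-out lower numbers stand for stronger inhibition and higher numbers for weaker inhibition), compound 1 (`COc1ccc2c(/C=C(\C)C(=O)c3cc(OC)c(OC)c([Se]C)c3)cn(C)c2c1`) gives 15 nM and compound 2 (`COc1ccc2c(/C=C(\C)C(=O)c3cc(OC)c(OC)c([Se]C)c3)c[nH]c2c1`) gives 8 nM on the same read-out, which leaves compound 2 level with its only measured neighbour. Among the measured compounds shown here, the single measured step is a 1.9-fold lower number from compound 1 to compound 2 (0.27 log units; within the scatter) and it concerns the aromatic nitrogen, so it sets no size for a change on the carbon ring. Compound 3 (`COc1cc(C(=O)/C(C)=C/c2c[nH]c3ccccc23)cc([Se]C)c1OC`) carries hydrogen in place of methoxy on an aromatic carbon of the shared core. For the measured compounds named here, the series holds no measured step at this carbon, so the expectation is loose. With compound 2 at 8 nM as the starting point, a moderate rise beyond the scatter is expected in this assay rather than a further fall. The expected change is a 3.8-fold higher number from compound 2 to compound 3 (0.57 log units; beyond the scatter) on this estimate. For compound 3 the estimated value is 30 nM with an expected range from 8 nM to 150 nM in these cells.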

Compound 3, half-maximal inhibitory concentration: 12 nM
For compound 3 the middle estimate is 2.5-fold (0.40 log units) above the measured one; measured number inside the range.
By their numbers in this assay, from the lowest: compounds 2, 3 and 1 (each within the scatter of the next).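

At this carbon of the shared core, the series now has its first measured step in this assay: hydrogen in place of methoxy gives a 1.5-fold higher number from compound 2 to compound 3 (0.18 log units; within the scatter) and stays within the scatter. On the background of compound 2, this methoxy can therefore be removed without a change that this read-out can separate from repeat measurements, so the group is not needed to keep the number in the range of compound 2. No measurement shown here gives a reason for this outcome.

Among these compounds, what a fluorine, an amine or a longer chain such as ethoxy would do at this carbon remains open, since hydrogen and methoxy are the only two groups compared here. Also open, going by these compounds, is whether the same replacement would read alike with the methyl on the aromatic nitrogen, as in compound 1.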